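An Oxolan-3-yl Group in Place of the Hydroxy Chain

This account rests on a few compounds, and the source may have more. Where it says the series, first, only, none or still open, it means among the compounds named here.

Compound 1 `Cc1nn(CC2(O)COC2)cc1Nc1nc(N)c2c(C#N)c(N3CCC[C@H]3C)n(C)c2n1` and compound 2 `Cc1c(Nc2nc(N)c3c(C#N)c(N4CCC[C@H]4C)n(C)c3n2)cnn1CC(C)(C)O` share one core and differ in the group on an aromatic nitrogen. In an assay on isolated protein for inhibition of Leucine-rich repeat serine/threonine-protein kinase 2 (Homo sapiens), read by TR-FRET and LanthaScreen, with stated times of 50 min and 30 min, in the presence of a further agent that is not named here (on this read-out higher numbers stand for weaker inhibition and lower numbers for stronger inhibition), compound 1 gives 57 nM, and compound 2 gives 43 nM. Compound 2 stands at the lower of the two numbers, yet compound 1 lies within the scatter of it, so the two cannot be set apart. Compound 3 `Cc1c(Nc2nc(N)c3c(C#N)c(N4CCC[C@H]4C)n(C)c3n2)cnn1[C@@H]1CCOC1` is not yet measured; it differs from compound 2 by oxolan-3-yl in place of 2-hydroxy-2-methylpropyl on an aromatic nitrogen. Within the data shown here, no step between measured compounds speaks to this change, so in this assay compound 3 is expected to show a step of a 1.2-fold higher number from compound 2 to compound 3 (0.07 log units; within the scatter) that stays within the scatter. Compound 3 is estimated at 50 nM, between 20 nM and 130 nM.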

Compound 3, half-maximal inhibitory concentration: 20 nM
Beside the measured number, compound 3's estimate is 2.5-fold (0.40 log units) above it, within the range that was stated.
By their numbers in this assay, from the lowest: compound 3; then compounds 2 and 1 (each within the scatter of the next).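

In this assay this position on the aromatic nitrogen responds to the change, which gives a 2.2-fold lower number from compound 2 to compound 3 (0.33 log units; beyond the scatter) as a modest step beyond the scatter. The hydrogen-bond donor leaves while the count of heavy atoms and the hydrogen-bond acceptor stay the same, so the open chain with its hydroxy group is not required for this level of inhibition. Nothing measured here accounts for the difference. From the compounds shown here alone, whether the ring or the loss of the donor matters remains open, as does the opposite stereocentre of oxolan-3-yl. Going by these compounds, how an amine such as piperidin-4-yl would behave at this position also remains open.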